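A few compounds are considered here, and "the series" means these few. Any claim that something is new, unique, unknown or untested is made for them only; others in the source may bear on it.

Measured so far in a functional assay on A-375 cells (Homo sapiens) for cytotoxicity, read by MTT assay, with a stated time of 48 h; on this read-out lower numbers stand for stronger inhibition and higher numbers for weaker inhibition:
- compound 1 `CC1(C)S[C@@H]2/C(=C\C(=O)c3ccc4ccccc4c3)C(=O)N2[C@H]1C(=O)OC(c1ccccc1)c1ccccc1` gives 36500 nM
- compound 2 `CC(=O)/C=C1/C(=O)N2[C@@H]1SC(C)(C)[C@@H]2C(=O)OC(c1ccccc1)c1ccccc1` gives 63000 nM

Compound 2 sits at the numerically higher of the two numbers, a gap to compound 1 that is within the scatter. Compound 3 `CC1(C)S[C@@H]2/C(=C\C(=O)OCc3ccccc3)C(=O)N2[C@H]1C(=O)OC(c1ccccc1)c1ccccc1` carries benzyloxy in place of methyl on a carbonyl carbon. Within the data shown here, the only step touching this carbonyl, a 1.7-fold higher number from compound 1 to compound 2 (0.24 log units; within the scatter), stayed within the scatter, and it is the one step that bears on the change. No step beyond the scatter is therefore expected in this assay. Compound 3 is expected at 45000 nM, between 15000 nM and 130000 nM. The implied step, a 1.4-fold lower number from compound 2 to compound 3 (0.15 log units; within the scatter), is an estimate only.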

Compound 3, half-maximal inhibitory concentration: 7100 nM
Compound 3: middle estimate off by 6.3-fold (0.80 log units), on the high side; the measured number lies below the stated range.
By their numbers in this assay, from the lowest: compound 3; then compounds 1 and 2 (each within the scatter of the next).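

In this assay, the group on this carbonyl carbon can move the number beyond the scatter: benzyloxy in place of methyl brings an 8.9-fold lower number from compound 2 to compound 3 (0.95 log units; beyond the scatter), and benzyloxy in place of naphthalen-2-yl brings a 5.1-fold lower number from compound 1 to compound 3 (0.71 log units; beyond the scatter). Carrying a ring is not enough in itself, since compound 1, with naphthalen-2-yl, stays within the scatter of compound 2, with methyl. Nothing available gives a reason for the shift.

Open, as far as these compounds go, is whether the oxygen link or the benzyl part goes with the lower number; methoxy or benzylamino on this carbonyl carbon would separate the two.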